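Ureido to carbamoyl on an aryl triazene

The source may report more compounds than this note shows. Statements on the series, on what has been measured and on what is new or still open speak of the compounds shown alone.

Measured compounds:
compound 1 `CC(C)N(C)/N=N/c1ccc(C(N)=O)cc1`, 3.17
compound 2 `C=CCN(C)/N=N/c1ccc(C(N)=O)cc1`, 3.38
compound 3 `CCN(C)/N=N/c1ccc(NC(N)=O)cc1`, 3.87

In a functional assay on L1210 cells (Mus musculus) for antiproliferative activity (a lower number here means a less potent compound, a higher number a more potent compound, by a factor of ten per unit of this negative logarithm), compound 3 gives the highest of the three numbers; compound 2 stands 3.38 and compound 1 stands 3.17, both beyond the scatter below compound 3. Compound 4 `CCN(C)/N=N/c1ccc(C(N)=O)cc1` is not yet measured. The change from compound 3 to compound 4 is carbamoyl in place of ureido on an aromatic carbon. Among the measured compounds shown here, no measured pair exchanges ureido for carbamoyl; the only measured step, a number 0.21 log units higher from compound 1 to compound 2 (within the scatter), concerns the amine nitrogen and is within the scatter, so it does not bear on this change. Compounds 1 and 2 carry carbamoyl and sit lower than compound 3, but they also differ from compound 3 at the amine nitrogen, so the two changes cannot be separated. Compound 4 is therefore expected to fall between the carbamoyl compounds and compound 3, at 3.5, with a range of 3 to 4. This estimate means a step of a number 0.37 log units lower from compound 3 to compound 4 (beyond the scatter).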

Compound 4, logarithm of the reciprocal of the active concentration, log(1/C): 3.66
For compound 4 the middle estimate is 0.16 log units below the measured one, within the range that was stated.
By their numbers in this assay, from the lowest: compounds 1, 2, 4 and 3 (each within the scatter of the next, the first and the last beyond it).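

Compound 3 and compound 4 now form a pair that isolates the change on the aromatic carbon in this assay: the step is a number 0.21 log units lower from compound 3 to compound 4 (within the scatter), so with the amine nitrogen unchanged, the exchange of ureido for carbamoyl stays inside the scatter. Among the compounds shown here, with carbamoyl held constant, the amine nitrogen can also be read for the first time: the step for ethyl in place of allyl is a number 0.28 log units higher from compound 2 to compound 4 (within the scatter), whereas the step for ethyl in place of isopropyl is a number 0.49 log units higher from compound 1 to compound 4 (beyond the scatter), the only one of the three beyond the scatter and modest in size. Nothing available here accounts for any of these steps. The compounds shown leave open how a carboxylic acid or an amine on the same aromatic carbon would read in this assay. They also leave open whether a longer chain on the amine nitrogen would continue the differences seen among the carbamoyl compounds.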